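Halogen swap on the aryl ring and microsomal stability

The source may report more compounds than this note shows. Statements on the series, on what has been measured and on what is new or still open speak of the compounds shown alone.

Compound 1 `FC(F)(F)c1ccc(NCCNc2ncc(-c3ncc[nH]3)c(-c3ccc(Cl)cc3Cl)n2)nc1` — > 0.5 h
Compound 2 `Nc1nc(NCCNc2ncc(-c3ncc[nH]3)c(-c3ccccc3Br)n2)ccc1[N+](=O)[O-]` — > 0.5 h
Compound 3 `Nc1nc(NCCNc2ncc(-c3ncc[nH]3)c(-c3cc(F)ccc3F)n2)ccc1[N+](=O)[O-]` — > 0.5 h

All three measured compounds share one core and differ only in the aryl group on an aromatic carbon of the six-membered ring with two nitrogens. In an ADME assay on microsomes from liver (Rattus norvegicus) for metabolic stability (a lower number here means that the compound disappears faster, a higher number that the compound lasts longer), compound 2 gives > 0.5 h, which is a limit of the assay and not a number. Compound 1 gives > 0.5 h, likewise a limit. Compound 3 gives > 0.5 h, also a limit. Among the compounds with values here, because of the limit of > 0.5 h in this assay, at which 3 of the 3 values shown sit, no measured step can be read: the step that the two limits leave unreadable from compound 2 to compound 3 is unreadable, since both ends sit at the limit, and no other compound departs from it.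

The new compound 4 `Nc1nc(NCCNc2ncc(-c3ncc[nH]3)c(-c3cc(F)c(Cl)cc3F)n2)ccc1[N+](=O)[O-]` differs from compound 2 by 4-chloro-2,5-difluorophenyl in place of 2-bromophenyl on an aromatic carbon. Within the data shown here, the only step that bears on this change is the one from compound 2 to compound 3, and its size is hidden by the limit, so no direction or size beyond the scatter can be read from the data; compound 1 with its trifluoromethyl-bearing ring offers no more.

Compound 4 is therefore expected to sit at the limit as well, with an estimated value of 1 h, its range running from 0.5 h to 3 h. The implied step from compound 2 is expected to be a step that the limit leaves unreadable from compound 2 to compound 4, which on these data cannot be distinguished from no change.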

Compound 4, half-life: > 0.5 h
Compound 4: a limit, no number (the forecaster's own chance of this, stated with the estimate: 80%); the middle value is on the limit's open side.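

In this assay compound 4 gives > 0.5 h, which is a limit of the assay and not a number. No step from compound 2 or compound 3 to compound 4 can be read, because every value stands at the same limit: the limit of > 0.5 h in this assay, at which 4 of the 4 values shown sit.

The compounds shown leave open how long any of them actually lasts in this assay, and whether the 4-chloro-2,5-difluorophenyl group makes any difference to that.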